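The compounds below may be only part of what the source reports. "The series", "measured", "known", "first", "only" and "open" are said of these compounds alone.

Measured so far: compound 1 `N#Cc1c(Nc2ccccc2F)nc(SCc2cn(Cc3ccccc3Cl)nn2)nc1-c1ccccc1` gives 8060 nM in a functional assay on MCF7 cells (Homo sapiens) for inhibition, read by MTT assay, with a stated time of 72 h; a lower number here means a stronger inhibitor, a higher number a weaker inhibitor; compound 2 `Cc1ccc(Cn2cc(CSc3nc(Nc4ccccc4F)c(C#N)c(-c4ccccc4)n3)nn2)cc1` gives > 64000 nM, a limit of this assay; compound 3 `Cc1ccc(Cn2cc(CSc3nc(Nc4ccc(C)cc4)c(C#N)c(-c4ccccc4)n3)nn2)cc1` gives > 64000 nM, also a limit.

Compound 2 and compound 1 share a core and differ in one place (2-chlorophenyl in place of 4-methylphenyl on a saturated chain carbon bound to an aromatic nitrogen). That change brought an at least 7.9-fold lower number from compound 2 to compound 1 (0.89 log units; beyond the scatter), a size that can be read only as a lower bound because of the limit of > 64000 nM in this assay, at which 2 of the 3 values shown sit. Compound 3 differs from compound 2 in another place (4-methylphenyl in place of 2-fluorophenyl on a nitrogen on an aromatic ring), and here a step that the two limits leave unreadable from compound 2 to compound 3.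

Compound 4 `Cc1ccc(Nc2nc(SCc3cn(Cc4ccccc4Cl)nn3)nc(-c3ccccc3)c2C#N)cc1` has not yet been measured. It stands to compound 3 as compound 1 stands to compound 2: the same change (2-chlorophenyl in place of 4-methylphenyl on a saturated chain carbon bound to an aromatic nitrogen), at the same place, on a core that differs only as described for compound 3 against compound 2. Compound 4 is therefore expected to sit around 16000 nM, a step of an at least 4.0-fold lower number from compound 3 to compound 4 (0.60 log units; beyond the scatter) that rests on compound 1 having given 8060 nM after the same change. Compound 3 offers only a limit, so the expected size of this second step remains uncertain.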

Compound 4, half-maximal inhibitory concentration: 9420 nM
The estimate for compound 4 lay 1.7-fold (0.23 log units) above the measured number, and the stated range covers the measured number.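

In this assay, the change from 4-methylbenzyl to 2-chlorobenzyl again lowered the number on the second core, with an at least 6.7-fold lower number from compound 3 to compound 4 (0.83 log units; beyond the scatter), so the direction carried over from one core to the other on these two pairs. It does not show that the size carried over, as both starting compounds, compound 2 and compound 3, sit at a limit: the same change on two cores in this assay, an at least 7.9-fold lower number (0.89 log units; beyond the scatter) from compound 2 to compound 1 and an at least 6.7-fold lower number (0.83 log units; beyond the scatter) from compound 3 to compound 4; the limit leaves it open whether they differ. With 2-chlorobenzyl in place, the change on the nitrogen on an aromatic ring gives a 1.2-fold higher number from compound 1 to compound 4 (0.07 log units; within the scatter), so these two compounds cannot be told apart, while the matching step between the two limits cannot be read.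

The compounds shown leave open whether the lower number goes with the chlorine itself or with the 2-chloro arrangement, which plain benzyl and 4-chlorobenzyl groups would help to separate. They also leave open whether the change would hold on a core bearing a morpholine or another aliphatic amine in place of the substituted aniline.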